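Compound 2 Takes 1-Benzofuran-2-yl in Place of Furan-3-yl

This account rests on a few compounds, and the source may have more. Where it says the series, first, only, none or still open, it means among the compounds named here.

Going by the values given here, only two measurements are available in a functional assay on HCT-116 cells (Homo sapiens), read by MTT assay, with a stated time of 72 h; a higher number here means a weaker inhibitor, a lower number a stronger inhibitor. Compound 1 `C#Cc1cn([C@@H]2O[C@H](CO)[C@@H](O)[C@H]2O)c2nc(N)nc(OC)c12` gives > 20000 nM, which is a limit of the assay and not a number. Among the compounds with values here, compound 2 `Nc1nc2c(c(-c3ccoc3)cn2[C@@H]2O[C@H](CO)[C@@H](O)[C@H]2O)c(=O)[nH]1` gives 17600 nM, the only actual number so far, and so it has no other measured number to be ranked against.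

Compound 3 `Nc1nc2c(c(-c3cc4ccccc4o3)cn2[C@@H]2O[C@H](CO)[C@@H](O)[C@H]2O)c(=O)[nH]1` keeps the shared core of compound 2 and carries 1-benzofuran-2-yl in place of furan-3-yl on an aromatic carbon. Within the data shown here, no pair of measured compounds differs in one place, so the size of this change in this assay has no measured precedent. With compound 2 at 17600 nM as the only anchor, no change beyond the scatter is expected. Compound 3 may well be reported only as a limit. The expected change, a 1.2-fold lower number from compound 2 to compound 3 (0.07 log units; within the scatter), is an estimate that stays within the scatter. For compound 3 the expected value is 15000 nM, with an estimated range from 5000 nM to 30000 nM.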

Compound 3, half-maximal inhibitory concentration: > 100000 nM
Compound 3 ended at the assay's limit; the forecaster's own chance of this, stated with the estimate: 50%; middle value at least 6.6-fold (0.82 log units) from the limit.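

In this assay, going by these compounds alone, the step at this position is the first that can be read, and it is an at least 5.6-fold higher number from compound 2 to compound 3 (0.75 log units; beyond the scatter). It shows that this aromatic carbon of the five-membered aromatic ring with 1 nitrogen is not indifferent to the group it carries, since a change from furan-3-yl to 1-benzofuran-2-yl, which brings in a six-membered aromatic ring of carbon only, moves the read-out beyond the scatter and towards a weaker inhibitor. The value of compound 3, > 100000 nM, is a limit of the assay and not a number, so the true size of the step stays unknown and only its lower bound is fixed: the limit of > 100000 nM in this assay, at which 1 of the 3 values shown sits.

The compounds shown leave open whether the higher number follows from the added ring or from the different point of attachment, and whether a small group such as methyl, an amine or a carboxylic acid on this carbon would give a lower number than compound 2 at 17600 nM. Compound 1 differs from the others in more than one place, so its steps to them cannot be read.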